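Trading a Dihydroxyphenyl for a Chlorophenyl on the Hydrazone

A few compounds are considered here, and "the series" means these few. Any claim that something is new, unique, unknown or untested is made for them only; others in the source may bear on it.

Of the compounds shown here, three sharing one core have been tested in a functional assay on MKN-45 cells (Homo sapiens) for cytotoxicity, read by MTT assay, with a stated time of 72 h; a higher number here means a weaker inhibitor, a lower number a stronger inhibitor. Compound 1 `CN(C)CCn1cnnc1-c1cc(Oc2ccc(NC(=O)N/N=C/c3c(Cl)cccc3Cl)cc2F)ccn1` carries a 2,6-dichlorophenyl on the carbon with a double bond to nitrogen and gives 160 nM in this assay. Compound 2 `CN(C)CCn1cnnc1-c1cc(Oc2ccc(NC(=O)N/N=C/c3ccc(F)cc3F)cc2F)ccn1` carries a 2,4-difluorophenyl there and gives 810 nM. Compound 3 `CN(C)CCn1cnnc1-c1cc(Oc2ccc(NC(=O)N/N=C/c3ccc(O)c(O)c3)cc2F)ccn1` carries a 3,4-dihydroxyphenyl at the same place and gives 3240 nM, the highest number of the three, which makes it the weakest of this small set. The step of a 20-fold higher number from compound 1 to compound 3 (1.31 log units; beyond the scatter) is large, and the step of a 4.0-fold higher number from compound 2 to compound 3 (0.60 log units; beyond the scatter) is modest; both show that, among these compounds, the dihydroxyphenyl goes with a higher number than a halogen-bearing phenyl.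

Compound 4 `CN(C)CCn1cnnc1-c1cc(Oc2ccc(NC(=O)N/N=C/c3ccc(Cl)cc3)cc2F)ccn1` has not yet been measured. Its change from compound 3 is 4-chlorophenyl in place of 3,4-dihydroxyphenyl on a carbon with a double bond to nitrogen. This reverses the kind of swap seen in those two steps: a halogen-bearing phenyl comes back in place of the hydroxyl-bearing ring. The steps from compound 1 and compound 2 to compound 3 therefore point to a lower number in this assay for compound 4, with a size somewhere between those two steps. The expected step is an 8.1-fold lower number from compound 3 to compound 4 (0.91 log units; beyond the scatter). Compound 4 is estimated at 400 nM, with a range from 150 nM to 1200 nM.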

Compound 4, half-maximal inhibitory concentration: 570 nM
The estimate for compound 4 lay 1.4-fold (0.15 log units) below the measured number; measured number inside the range.
By their numbers in this assay, from the lowest: compound 1; then compounds 4 and 2 (each within the scatter of the next); then compound 3.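

In this assay, the step of a 5.7-fold lower number from compound 3 to compound 4 (0.75 log units; beyond the scatter) shows that the lower number seen with two halogens on the ring also appears with a single chlorine, so a second halogen is not required for compounds 1, 2 and 4 to sit below compound 3, and none of the four goes against this. The step of a 1.4-fold lower number from compound 2 to compound 4 (0.15 log units; within the scatter) cannot separate the 4-chlorophenyl from the 2,4-difluorophenyl, whereas the step of a 3.6-fold higher number from compound 1 to compound 4 (0.55 log units; beyond the scatter) shows that a chlorine on this ring is not enough in itself to match the 2,6-dichlorophenyl of compound 1, which remains the strongest of the four. Nothing shown here gives a measured reason for any of these differences.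

Compound 1 and compound 4 differ in both the number of chlorines and where they sit, so these data cannot tell which of the two changes goes with the lower number of compound 1. As far as these compounds go, how a phenyl ring carrying a methoxy group, an amine or a carboxylic acid would fall in this assay also remains open.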